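Chloro for Methyl on the Benzimidazole-Bearing Ring

This account rests on a few compounds, and the source may have more. Where it says the series, first, only, none or still open, it means among the compounds named here.

Compound 1 `Cc1ccc(NC(=O)NC(=O)c2ccc(OCc3ccccc3)cc2)cc1-c1nc2ccccc2[nH]1` gives 39400 nM
Compound 2 `Cc1ccc(NC(=O)NC(=O)c2ccc(OCc3ccc(F)cc3)cc2)cc1-c1nc2ccccc2[nH]1` gives 160 nM

Within the data shown here, in a functional assay on MGC-803 cells (Homo sapiens) for inhibition, read by MTT assay, with a stated time of 48 h (a higher number here means a weaker inhibitor, a lower number a stronger inhibitor), compound 2 stands lowest of the two numbers; the only measured step, a 250-fold lower number from compound 1 to compound 2 (2.39 log units; beyond the scatter), concerns a fluoro on the benzyl ring. Compound 3 `O=C(NC(=O)c1ccc(OCc2ccc(F)cc2)cc1)Nc1ccc(Cl)c(-c2nc3ccccc3[nH]2)c1` differs from compound 2 by chloro in place of methyl on an aromatic carbon. Among the measured compounds shown here, no measured step touches this position, so the fluoro step offers no direct guide for it. Compound 3 is therefore expected to stay close to compound 2, with the step of a 1.3-fold higher number from compound 2 to compound 3 (0.10 log units; within the scatter) expected to lie within the scatter. The estimate for compound 3 is 200 nM, expected between 50 nM and 800 nM.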

Compound 3, half-maximal inhibitory concentration: 61 nM
Compound 3: middle estimate off by 3.3-fold (0.52 log units), on the high side; measured number inside the range.
By their numbers in this assay, from the lowest: compound 3; then compound 2; then compound 1.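

In this assay, the position ortho to the 1H-benzimidazol-2-yl group and para to a large group responds to a small change: chloro in place of methyl gives a 2.6-fold lower number from compound 2 to compound 3 (0.42 log units; beyond the scatter). Methyl is therefore not needed here for activity in these cells, and chloro does modestly better. No available evidence accounts for this gain.

As far as these compounds go, whether other groups at this position, such as bromo, methoxy or an amine, would do better or worse remains open. From the compounds shown here alone, it is also open whether chloro would give a similar step without the fluoro on the benzyl ring.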